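A few compounds are considered here, and "the series" means these few. Any claim that something is new, unique, unknown or untested is made for them only; others in the source may bear on it.

Compound 1, `Cc1nc(N)c2c(-c3ccccc3)cn([C@@H]3O[C@H](CO)[C@@H](O)[C@H]3O)c2n1`, in a functional assay on HCT-116 cells (Homo sapiens), read by MTT assay, with a stated time of 72 h (on this read-out lower numbers stand for stronger inhibition and higher numbers for weaker inhibition), gives > 100000 nM, which is a limit of the assay and not a number. Compound 2, `Cc1nc(N)c2c(-c3ccsc3)cn([C@@H]3O[C@H](CO)[C@@H](O)[C@H]3O)c2n1`, gives > 20000 nM in this assay, again a limit. The change between them is thiophen-3-yl in place of phenyl on an aromatic carbon, and the step that the two limits leave unreadable from compound 1 to compound 2 cannot be sized, since one value sits at the limit of > 100000 nM in this assay, at which 1 of the 3 values shown sits, and the other at the limit of > 20000 nM in this assay, at which 2 of the 3 values shown sit. Compound 3, `Nc1nc2c(c(-c3ccccc3)cn2[C@@H]2O[C@H](CO)[C@@H](O)[C@H]2O)c(=O)[nH]1`, gives > 20000 nM in this assay, also a limit; the difference between its core and that of compound 1 is not broken down here. Compound 4, `Nc1nc2c(c(-c3ccsc3)cn2[C@@H]2O[C@H](CO)[C@@H](O)[C@H]2O)c(=O)[nH]1`, repeats on the core of compound 3 the same change, (thiophen-3-yl in place of phenyl on an aromatic carbon). With every value shown being a limit, compound 4 is expected to stay near the limit as well, a step estimated at a step that the limit leaves unreadable from compound 3 to compound 4. Compound 4 is therefore estimated at 50000 nM, between 15000 nM and 200000 nM.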

Compound 4, half-maximal inhibitory concentration: > 20000 nM
Compound 4 was reported as a limit; the forecaster's own chance of this, stated with the estimate: 85%; the middle value is on the limit's open side.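

Compound 3 and compound 4 are both reported only as limits, so the step between them, thiophen-3-yl in place of phenyl, cannot be read. The compounds shown leave open whether either group, on either core, gives a measurable value in this assay.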